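Triazole substituent removal in a butenolide series

The source may report more compounds than this note shows. Statements on the series, on what has been measured and on what is new or still open speak of the compounds shown alone.

Measured compounds:
- compound 1, `CC(C)(C)OC(=O)N1CCN(C(=S)SCc2cn(C[C@H](O)[C@H]3OC(=O)C(OCc4ccccc4)=C3OCc3ccccc3)nn2)CC1`: > 100000 nM
- compound 2, `COc1ccc(-c2cn(C/C=C3\OC(=O)C(OCc4ccccc4)=C3OCc3ccccc3)nn2)cc1`: > 100000 nM
- compound 3, `CCCCCCCCCCc1cn(C[C@H](O)[C@H]2OC(=O)C(OCc3ccccc3)=C2OCc2ccccc2)nn1`: 6750 nM

In a functional assay on A549 cells (Homo sapiens) for antiproliferative activity, read by MTT assay, with a stated time of 72 h (on this read-out lower numbers stand for stronger inhibition and higher numbers for weaker inhibition), compound 1 reaches only a limit of the assay, > 100000 nM. Compound 2 likewise gives only a limit in this assay, > 100000 nM. Going by the values given here, compound 3 is the single member of the set with a measured number in this assay, 6750 nM; the two other values sit at the limit of > 100000 nM in this assay, at which 2 of the 3 values shown sit, so compound 3 is the only point from which a step can be read at all.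

Compound 4, `O=C1O[C@H]([C@@H](O)Cn2ccnn2)C(OCc2ccccc2)=C1OCc1ccccc1`, has not yet been run in this assay. It differs from compound 3 in one place: hydrogen in place of decyl on an aromatic carbon. Whether the decyl chain is what carries the measured number for compound 3 cannot be read from the shown values, since no step between measured compounds is available; the two limits of compound 1 and compound 2 show only that other substitution at the same ring carbon gives no measurable inhibition.

The step from compound 3 to compound 4 is expected to be a clear loss, a 12-fold higher number from compound 3 to compound 4 (1.07 log units; beyond the scatter), beyond the usual scatter. Compound 4 is expected to give about 80000 nM in this assay, between 20000 nM and 300000 nM, with a real chance that only a limit is returned.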

Compound 4, half-maximal inhibitory concentration: > 100000 nM
Compound 4 ended at the assay's limit (the forecaster's own chance of this, stated with the estimate: 60%); middle value at least 1.2-fold (0.09 log units) away from the limit.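

In this assay, going by these compounds alone, hydrogen in place of decyl on the aromatic carbon gives an at least 14-fold higher number from compound 3 to compound 4 (1.17 log units; beyond the scatter), the first step at this position with a single change and a measured starting point. The measurable inhibition of compound 3 therefore depends on the decyl chain, and the core of compound 4 without a substituent at this carbon gives no measured number in this series. The earlier limits showed only that two other substituted compounds gave no number, whereas compound 4 now serves as the unsubstituted reference and marks the size of the step as a lower bound, with its upper end resting on a limit and not on a number: the limit of > 100000 nM in this assay, at which 3 of the 4 values shown sit.

The compounds shown leave open how the effect depends on chain length, and whether an octyl or dodecyl chain at this carbon would give a lower or a higher number than compound 3. Also open, going by these compounds, is whether a decyl chain ending in an amine or a carboxylic acid would keep the inhibition, and whether decyl on the core of compound 2 would give a measured number.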